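The source may report more compounds than this note shows. Statements on the series, on what has been measured and on what is new or still open speak of the compounds shown alone.

Three compounds of this study share one core: compound 1 `COc1cc(/C=N/Nc2nc(-c3cccc(Br)c3)cs2)cc(Br)c1OC`, compound 2 `Fc1ccc(/C=N/Nc2nc(-c3ccc(Br)cc3)cs2)cc1F` and compound 3 `COc1cc(/C=N/Nc2nc(-c3cccc(Br)c3)cs2)c(Br)c(Br)c1OC`. All three were tested in an ADME assay on HUVEC cells (Homo sapiens) for inhibition, read by MTT assay, with a stated time of 48 h; on this read-out higher numbers stand for weaker inhibition and lower numbers for stronger inhibition. In this assay compound 1 gives only a limit, > 100000 nM. In this assay compound 2 likewise gives only a limit, > 100000 nM. In this assay compound 3 also gives only a limit, > 100000 nM. Compound 3 and compound 1 differ in one place (hydrogen in place of bromo on an aromatic carbon); the step that the two limits leave unreadable from compound 3 to compound 1 has no readable size because of the limit of > 100000 nM in this assay, at which 3 of the 3 values shown sit. How the core of compound 2 differs from the core of compound 3 is not broken down here.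

Compound 4 `Fc1ccc(/C=N/Nc2nc(-c3ccccc3)cs2)cc1F` has not yet been measured in this assay. It differs from compound 2 in one place (hydrogen in place of bromo on an aromatic carbon). Among the measured compounds shown here, this is the same kind of change as the one from compound 3 to compound 1, but the surroundings differ: in compound 3 the carbon that loses its bromo is ortho to a bromo group, ortho to a large group, meta to a methoxy group and para to a methoxy group, whereas in compound 2 it is para to a large group.

The expectation for compound 4 rests on the three measured values all sitting at the limit and on the earlier step being unreadable. The step from compound 2 to compound 4 is expected to be a number no higher from compound 2 to compound 4 (the limit leaves the size open). Compound 4 is estimated at 100000 nM, with a plausible range from 30000 nM to 300000 nM, and this assay will most likely again report only a limit for it.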

Compound 4, half-maximal inhibitory concentration: > 100000 nM
Compound 4: no number, only a limit (the forecaster's own chance of this, stated with the estimate: 85%); the middle value sits exactly at the limit.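

In this assay compound 4 gives only a limit, > 100000 nM, not a number. No size can be read for the step between compound 2 and compound 4 because their values are both limits: the limit of > 100000 nM in this assay, at which 4 of the 4 values shown sit.

The compounds shown leave open how strongly any of them inhibits in this assay, and so what the change from 4-bromophenyl to phenyl does to that inhibition.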